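From a Chlorophenyl to a Benzyl Group on a Shared Core

A few compounds are considered here, and "the series" means these few. Any claim that something is new, unique, unknown or untested is made for them only; others in the source may bear on it.

Compound 1 `Cc1cccc(-c2nnc(SCCCN3CCN(c4ccccn4)CC3)[nH]2)c1` in a functional assay on THP-1 cells (Homo sapiens) for cytotoxicity, read by MTT assay, with a stated time of 24 h (on this read-out higher numbers stand for weaker inhibition and lower numbers for stronger inhibition), gives > 300000 nM, which is a limit of the assay and not a number.
Compound 2 `Clc1ccccc1-c1nnc(SCCCN2CCN(c3ccccn3)CC2)[nH]1` in this assay gives > 300000 nM, again a limit rather than a number.

Compound 2 thus stands only at a limit, and every value shown so far sits at the same place, as the limit of > 300000 nM in this assay, at which 2 of the 2 values shown sit, records. Going by the values given here, the single measured step, a step that the two limits leave unreadable from compound 1 to compound 2, swaps a 3-methylphenyl for a 2-chlorophenyl on an aromatic carbon. Both of its ends are limits, and its size cannot be read.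

Compound 3 `c1ccc(Cc2nnc(SCCCN3CCN(c4ccccn4)CC3)[nH]2)cc1` has not yet been measured. It differs from compound 2 by benzyl in place of 2-chlorophenyl on an aromatic carbon. Among the compounds with values here, no measured step gives a readable size for a change of this kind, so no direction and no size beyond the scatter can be predicted; the only guide is that compound 2 itself sits at the limit. The step expected in this assay is therefore a number no higher from compound 2 to compound 3 (the limit leaves the size open). Compound 3 is estimated at 300000 nM, with a range from 100000 nM to 1000000 nM, and most likely it will again be reported only as a limit.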

Compound 3, half-maximal inhibitory concentration: > 300000 nM
Compound 3: a limit, no number; the forecaster's own chance of this, stated with the estimate: 85%; the middle value sits exactly at the limit.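

Compound 3 gives > 300000 nM in this assay, which is a limit and not a number. Going by these compounds alone, the steps linking compound 1, compound 2 and compound 3 therefore cannot be read, so this result adds no new step. Whether these three compounds differ at all in this assay stays open, because all their values rest at one place: the limit of > 300000 nM in this assay, at which 3 of the 3 values shown sit.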